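From a Hydroxycyclohexyl Amide to an Aminocyclopentyl Amide

The source may hold more compounds than are shown below. What is called first, only, known or untested is meant among the compounds shown, and "the series" means these compounds.

The measured compounds, with their numbers in an assay for inhibition of MAP/microtubule affinity-regulating kinase 3 (Homo sapiens), read by HTRF, with a stated time of 2 h; on this read-out higher numbers stand for weaker inhibition and lower numbers for stronger inhibition:
compound 1 `Cn1cc(-c2cnc3c(-c4csc(C(=O)N[C@@H]5CCCC[C@H]5O)c4)cnn3c2)cn1`: 24 nM
compound 2 `Cn1cc(-c2cnc3c(-c4csc(C(=O)NC(CO)C5CC5)c4)cnn3c2)cn1`: 9 nM
compound 3 `Cc1sc(C(=O)N[C@@H]2CCCC[C@@H]2N)cc1-c1cnn2cc(-c3cnn(C)c3)cnc12`: 1.3 nM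

Compound 1 carries the highest number of the three in this assay; compound 2 sits nearest to it and compound 3 furthest away. Compound 4 `Cn1cc(-c2cnc3c(-c4csc(C(=O)N[C@@H]5CCC[C@@H]5N)c4)cnn3c2)cn1` is built from compound 1 by one change: a group of 6 heavy atoms (5 carbon, 1 nitrogen; one five-membered non-aromatic ring of carbon only) in place of a group of 7 heavy atoms (6 carbon, 1 oxygen; one six-membered non-aromatic ring of carbon only), on an amide-type nitrogen. The group that leaves is a 2-hydroxycyclohexyl; the group that enters carries a nitrogen instead of the oxygen and a smaller ring.

Within the data shown here, only one measured step changes the same amide position, a 2.7-fold lower number from compound 1 to compound 2 (0.43 log units; beyond the scatter), a modest gain. Compound 3 also carries a nitrogen on its ring, but it differs in a second place as well from the other measured compounds, so the value of compound 3, 1.3 nM, can only hint at what the nitrogen contributes. On that basis a gain beyond the scatter is expected for compound 4, with a 4.8-fold lower number from compound 1 to compound 4 (0.68 log units; beyond the scatter). The estimate for compound 4 in this assay is therefore 5 nM, within a range from 1.5 nM to 15 nM.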

Compound 4, half-maximal inhibitory concentration: 2 nM
Compound 4: the middle estimate sits 2.5-fold (0.40 log units) above what was measured, and the stated range covers the measured number.
By their numbers in this assay, from the lowest: compounds 3 and 4 (each within the scatter of the next); then compound 2; then compound 1.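

In this assay, replacing the 2-hydroxycyclohexyl on the amide-type nitrogen with the aminated five-membered carbon ring gives a 12-fold lower number from compound 1 to compound 4 (1.08 log units; beyond the scatter), a large step and the biggest seen so far at this position. The same entering group also beats the group with the three-membered ring, with a 4.5-fold lower number from compound 2 to compound 4 (0.65 log units; beyond the scatter), so the gain is not confined to a comparison with the 2-hydroxycyclohexyl. This amide position therefore responds far more strongly than the earlier modest step suggested.

The change swaps oxygen for nitrogen and a six-membered ring for a five-membered ring at once, and a 2-hydroxycyclopentyl on the same core would be needed to separate the ring size from the atom. Nothing available here explains why this step is so large.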